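From compound 3 to compound 4 in the cytotoxicity assay

A few compounds are considered here, and "the series" means these few. Any claim that something is new, unique, unknown or untested is made for them only; others in the source may bear on it.

Three compounds have numbers in a functional assay on DU-145 cells (Homo sapiens) for cytotoxicity, read by MTT assay, with a stated time of 72 h; a higher number here means a weaker inhibitor, a lower number a stronger inhibitor. Compound 1 `COc1ccc(C(=O)c2cc(OC)c(OC)c(OC)c2)cc1N` gives 2100 nM. Compound 2 `COc1cccc(/C=C/C(=O)Nc2cc(OC)c(OC)c(OC)c2)c1` gives 3200 nM. Compound 3 `COc1ccc(C(=O)c2cc(OC)c(OC)c(OC)c2)cc1NC(=O)/C=C/c1cc(OC)c(OC)c(OC)c1`, which joins the two motifs of the first pair into one molecule, gives 6300 nM. The gap between compound 3 and compound 1 lies beyond the usual scatter of this assay, while the gap between compound 3 and compound 2 lies within it, so compound 3 and compound 2 cannot be ranked against each other on these numbers.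

Compound 4 `COc1ccc(/C=C/C(=O)Nc2cc(C(=O)c3cc(OC)c(OC)c(OC)c3)ccc2OC)cc1` keeps the core of compound 3 and differs in one place: 4-methoxyphenyl in place of 3,4,5-trimethoxyphenyl on a double-bonded chain carbon bound to a double-bonded chain carbon. Among the measured compounds shown here, no measured pair in this set shows this same change on its own, so the size of the step cannot be read from the data. On that basis the expectation is a step of no more than the scatter, in either direction, written as a 1.1-fold lower number from compound 3 to compound 4 (0.05 log units; within the scatter). Compound 4 is therefore estimated at 5600 nM in this assay, in a range from 2200 nM to 14000 nM.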

Compound 4, half-maximal inhibitory concentration: 12800 nM
Compound 4: middle estimate off by 2.3-fold (0.36 log units), on the low side, and the stated range covers the measured number.
By their numbers in this assay, from the lowest: compounds 1, 2 and 3 (each within the scatter of the next, the first and the last beyond it); then compound 4.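

In this assay, the swap of 3,4,5-trimethoxyphenyl for 4-methoxyphenyl on a double-bonded chain carbon bound to a double-bonded chain carbon gives a 2.0-fold higher number from compound 3 to compound 4 (0.31 log units; beyond the scatter), a modest step and the first in this set to isolate a change in one place. It shows that the group at this position is not interchangeable on this core: with the rest of the molecule held fixed, the smaller 4-methoxyphenyl goes with the weaker result. Nothing available here explains why the number rises at this position.

The compounds shown leave open whether an unsubstituted phenyl at this place would move the number further in the same direction, or whether a hydroxyl group or an amine on the ring would bring it back down. They also leave open whether the same step would appear on a different core.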